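Swapping a hydroxy for a chloro on the terminal phenyl

The source may hold more compounds than are shown below. What is called first, only, known or untested is meant among the compounds shown, and "the series" means these compounds.

Within the data shown here, compound 2 `COc1cc(NC(C)CCCNC(=O)NNC(=O)Nc2ccc(O)cc2)c2ncccc2c1` gives 111000 nM in a functional assay on CCRF-CEM cells (Homo sapiens) for inhibition, read by MTT assay, with a stated time of 72 h (a higher number here means a weaker inhibitor, a lower number a stronger inhibitor), the highest of the three numbers known. Compound 1 `COc1cc(NC(C)CCCNC(=O)NNC(=O)Nc2cc(C(F)(F)F)cc(C(F)(F)F)c2)c2ncccc2c1` gives 13000 nM, and compound 3 `COc1cc(NC(C)CCCNC(=O)Nc2cccc(F)c2)c2ncccc2c1` gives 21000 nM. Compound 4 `COc1cc(NC(C)CCCNC(=O)NNC(=O)Nc2ccc(Cl)cc2)c2ncccc2c1` differs from compound 2 by chloro in place of hydroxy on an aromatic carbon. The step of a 5.3-fold lower number from compound 2 to compound 3 (0.72 log units; beyond the scatter) shows that replacing the terminal group at this end of the chain can move the number well beyond the scatter, and compound 1, carrying two trifluoromethyl groups on its terminal phenyl, sits clearly below compound 2. A lower number is therefore expected for compound 4, by about a 3.7-fold lower number from compound 2 to compound 4 (0.57 log units; beyond the scatter). Compound 4 is estimated at 30000 nM, within 10000 nM to 100000 nM.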

Compound 4, half-maximal inhibitory concentration: 108000 nM
The estimate for compound 4 lay 3.6-fold (0.56 log units) below the measured number; the whole stated range lies below it.
By their numbers in this assay, from the lowest: compounds 1 and 3 (each within the scatter of the next); then compounds 4 and 2 (each within the scatter of the next).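

In this assay the exchange of hydroxy for chloro gives a 1.0-fold lower number from compound 2 to compound 4 (0.01 log units; within the scatter) and so does not separate these two groups on this aromatic carbon, para to a large group. By contrast, putting ((4-chlorophenyl)carbamoyl)amino in place of 3-fluorophenyl gives a 5.1-fold higher number from compound 3 to compound 4 (0.71 log units; beyond the scatter) on the amide-type nitrogen, so at this end of the chain exchanging the whole terminal piece moves the number where this single-atom swap does not. Nothing measured here bears on the reason for either result. From the compounds shown here alone, whether an amine or a carboxylic acid on the same aromatic carbon would also leave the number unmoved stays open.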